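The source may hold more compounds than are shown below. What is called first, only, known or untested is meant among the compounds shown, and "the series" means these compounds.

Measured compounds in a functional assay on HeLa cells (Homo sapiens) for antiproliferative activity, with a stated time of 48 h; a lower number here means a stronger inhibitor, a higher number a weaker inhibitor:

- compound 1, `C=C(Br)C(=O)Nc1ccc(C(=O)/C=C/c2ccc(OC)cc2OC)cc1`: 1100 nM
- compound 2, `C=C(Br)C(=O)Nc1ccc(C(=O)/C=C/c2ccc(OC)c(OC)c2OC)cc1`: 510 nM
- compound 3, `Nc1ccc(C(=O)/C=C/c2ccccc2)cc1`: 7700 nM

Compound 1 and compound 2 share one core and differ in a single place: methoxy in place of hydrogen on an aromatic carbon. This change produced a 2.2-fold lower number from compound 1 to compound 2 (0.33 log units; beyond the scatter). Compound 3 stands on another core; the difference between the core of compound 3 and the core of compound 1 is not broken down here. In this assay compound 3 gives 7700 nM, the highest number of the three, and both compound 1 and compound 2 sit well beyond the scatter from it.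

Compound 4, `COc1cccc(/C=C/C(=O)c2ccc(N)cc2)c1`, is not yet measured. It differs from compound 3 by methoxy in place of hydrogen on an aromatic carbon. The same kind of change has already been made once, from compound 1 to compound 2, but not at the same surroundings: in compound 2 the entering group sits ortho to two methoxy groups (2 heavy atoms each) and meta to a large group, whereas in compound 4 it sits only meta to a large group, on a ring that otherwise carries nothing. The two changes are therefore the same kind of change, not the same.

For the measured compounds named here, for compound 4 a modest lowering of the number is expected, a 1.5-fold lower number from compound 3 to compound 4 (0.19 log units; within the scatter), judged beside the earlier step, because a 2.2-fold lower number from compound 1 to compound 2 (0.33 log units; beyond the scatter) is the only precedent and it was itself modest; a different core and a bare ring make a smaller or absent effect plausible, so the range is kept wide. Compound 4 is estimated at 5000 nM in this assay, expected between 2500 nM and 12000 nM.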

Compound 4, half-maximal inhibitory concentration: 19000 nM
Estimate against measurement, compound 4: 3.8-fold (0.58 log units) below; measured number above the stated range.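

In this assay, methoxy in place of hydrogen on an aromatic carbon gave a 2.5-fold higher number from compound 3 to compound 4 (0.39 log units; beyond the scatter), so the change did not keep its direction from one core to the other: the same change on two cores in this assay, a 2.2-fold lower number (0.33 log units; beyond the scatter) from compound 1 to compound 2 and a 2.5-fold higher number (0.39 log units; beyond the scatter) from compound 3 to compound 4, 5.3-fold (0.73 log units) apart, beyond the scatter of two such steps

For this series, the result from the core of compound 1 therefore cannot be carried to the core of compound 3 as a general gain from adding methoxy, not even in direction. It does not show that the core alone sets the direction, since the two pairs also differ in what else the receiving ring carries, and the data cannot separate these two differences with one pair on each core.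

Open, as far as these compounds go, is whether a single methoxy on an otherwise bare ring would also raise the number on the core of compound 1, which would separate the role of the core from that of the surrounding methoxy groups. Also open, from the compounds shown here alone, is whether a hydroxy group or a chlorine atom in the same place on the core of compound 3 would move the number in the same direction as methoxy or in the opposite one.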